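The compounds below may be only part of what the source reports. "The series", "measured", "known", "first", "only" and "open" are said of these compounds alone.

Of the compounds shown here, three built on a shared core have been tested in an ADME assay on MT4 cells (Homo sapiens) for cytotoxicity, read by MTT assay, with a stated time of 5 days; a higher number here means that more compound is tolerated, a lower number that less compound is tolerated. Compound 1 `Cc1cc(/C=C/C#N)cc(C)c1Oc1nc(Nc2ccc(N3CCN(S(N)(=O)=O)CC3)cc2)nc2ccsc12` reaches only a limit in this assay, at > 222000 nM. Compound 3 `Cc1cc(/C=C/C#N)cc(C)c1Oc1nc(Nc2ccc(N3CCN(S(C)(=O)=O)CC3)cc2)nc2ccsc12` differs from compound 1 in a single place, a methyl in place of an amino on a sulfonyl sulfur, and in this assay compound 3 gives 11500 nM. The measured step of an at least 19-fold lower number from compound 1 to compound 3 (1.28 log units; beyond the scatter) is large and runs toward a lower number, meaning less compound is tolerated.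

Compound 2 `Cc1cc(/C=C/C#N)cc(C)c1Oc1nc(Nc2ccc(CN3CCN(S(N)(=O)=O)CC3)cc2)nc2sccc12` likewise reaches only a limit in this assay, at > 217000 nM. Its position is therefore the limit described as the limit of > 217000 nM in this assay, at which 1 of the 3 values shown sits, which leaves its true number unknown.

From compound 2 to compound 4 `Cc1cc(/C=C/C#N)cc(C)c1Oc1nc(Nc2ccc(N3CCCC(NS(C)(=O)=O)C3)cc2)nc2sccc12` the change is 3-(methanesulfonamido)piperidin-1-yl in place of (4-sulfamoylpiperazin-1-yl)methyl on an aromatic carbon. Among the measured compounds shown here, the entering group carries a methyl on a sulfonyl sulfur, the same feature that distinguishes compound 3 from compound 1, and that is the only measured step that bears on this change. A step in the same direction is therefore expected, roughly an at least 10-fold lower number from compound 2 to compound 4 (1.03 log units; beyond the scatter), though the difference in the ring itself adds uncertainty. Compound 4 is estimated at 20000 nM in this assay, with a likely range from 5000 nM to 150000 nM.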

Compound 4, half-maximal cytotoxic concentration: 112000 nM
Beside the measured number, compound 4's estimate is 5.6-fold (0.75 log units) below it; the measured number falls inside the stated range.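

In this assay compound 4 gives a true number, 112000 nM, so this side of the series now has a measured value to work from. The change is an at least 1.9-fold lower number from compound 2 to compound 4 (0.28 log units; that floor lies within the scatter), which, set against an at least 19-fold lower number from compound 1 to compound 3 (1.28 log units; beyond the scatter), means that a methyl on a sulfonyl sulfur does not here come with a step that can be read as beyond the scatter, and the exchange on the aromatic carbon may or may not lower the number. As far as these compounds go, the true size of the step could be much larger than its floor, and it stays unknown since compound 2 stands at a limit: the limit of > 217000 nM in this assay, at which 1 of the 4 values shown sits.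

From the compounds shown here alone, what remains open is which part of the exchange matters, as the ring, the methyl and the way the group is attached to the aromatic carbon all differ at once between compound 2 and compound 4. An amino in place of the methyl on the sulfonyl sulfur of compound 4, or an ethyl there, would change one feature alone and show how much that single feature moves the number.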